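Replacing the Nitrile on the Ether Chain with a Dimethylamide

The source may hold more compounds than are shown below. What is called first, only, known or untested is meant among the compounds shown, and "the series" means these compounds.

For the measured compounds named here, compound 1 `CCc1cc(C(C)=O)c(O)cc1OCCCCC#N` has the higher of the two numbers measured so far. In an assay on isolated protein for inhibition of leukotriene B4 receptor 1 (Homo sapiens), tested at 10 uM (a higher number here means more inhibition at the concentration tested (going by the name of the read-out), a lower number less inhibition), compound 1 gives 92%, while compound 2 `CCCCCc1cc(C(C)=O)c(O)cc1OCCCCC#N` gives 31%. Going by the values given here, the single measured step, a number 61 percentage points lower from compound 1 to compound 2 (beyond the scatter), is a propyl in place of hydrogen on a saturated chain carbon, two bonds along the chain from an aromatic carbon, and so concerns the ring substituent rather than the chain that ends in cyano. Compound 3 `CCc1cc(C(C)=O)c(O)cc1OCCCCCCC(=O)N(C)C` departs from compound 1 elsewhere: 2-(dimethylcarbamoyl)ethyl in place of cyano on a saturated chain carbon, four bonds along the chain from an oxygen on an aromatic ring. Among the compounds with values here, no measured step touches a saturated chain carbon four bonds along the chain from an oxygen on an aromatic ring, so the measured step offers no direct guide. Because compound 1 already gives 92%, little room remains upward, and a moderate decrease is expected, a number 22 percentage points lower from compound 1 to compound 3 (beyond the scatter). Compound 3 is therefore estimated at 70%, with a range from 35% to 95%.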

Compound 3, a percentage reported as inhibition, at one concentration (the size of the read-out at that concentration, not a potency): 100%
For compound 3 the middle estimate is 30 percentage points below the measured one, outside the stated range (above it).
By their numbers in this assay, from the lowest: compound 2; then compounds 1 and 3 (each within the scatter of the next).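

In this assay the change on a saturated chain carbon, four bonds along the chain from an oxygen on an aromatic ring, gives a number 8 percentage points higher from compound 1 to compound 3 (within the scatter), so cyano and 2-(dimethylcarbamoyl)ethyl cannot be told apart here, although the entering group has 7 heavy atoms against 2 for the one leaving. For the compounds shown here, the far end of the ether chain therefore accepts this larger group with no step beyond the scatter, whereas the one earlier step, on the ring substituent, lay beyond it. No evidence at hand explains why the two end groups give such similar numbers.

On these data alone, whether a carboxylic acid or an amine at the chain end would give a similar number remains open. So does whether 2-(dimethylcarbamoyl)ethyl would behave the same way on the core of compound 2.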